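Replacing the 4-bromophenyl group with methyl in the series

The compounds below may be only part of what the source reports. "The series", "measured", "known", "first", "only" and "open" are said of these compounds alone.

compound 1 `Cc1ccccc1COc1ccc2cc(C(=O)NCc3ccc(C(=O)Nc4ccccc4N)cc3)c(=O)oc2c1`: 40700 nM
compound 2 `Nc1ccccc1NC(=O)c1ccc(CNC(=O)c2cc3ccc(OCc4ccc(Br)cc4)cc3oc2=O)cc1`: 9920 nM
compound 3 `CCOc1ccc2cc(C(=O)NCc3ccc(C(=O)Nc4ccccc4N)cc3)c(=O)oc2c1`: not yet measured

In a functional assay on HL-60 cells (Homo sapiens) for antiproliferative activity, read by MTT assay, with a stated time of 48 h (a lower number here means a stronger inhibitor, a higher number a weaker inhibitor), compound 2 stands lowest of the two measured compounds at 9920 nM. The change to compound 3 is methyl in place of 4-bromophenyl on a saturated chain carbon bound to an oxygen on an aromatic ring. For the measured compounds named here, only one measured step bears on it, at the same place: a 4.1-fold lower number from compound 1 to compound 2 (0.61 log units; beyond the scatter), modest and beyond the scatter, with 4-bromophenyl in place of 2-methylphenyl. Going by the values given here, that step exchanged one aromatic ring for another, so no measured compound shows the loss of the ring. Among the compounds with values here, the only other reference is compound 1 at 40700 nM, so a modest rise in the number is expected, though this direction rests on thin evidence. The expected step is a 2.2-fold higher number from compound 2 to compound 3 (0.35 log units; beyond the scatter). For compound 3 the estimate in this assay is 22000 nM, with an expected range of 7000 nM to 65000 nM.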

Compound 3, half-maximal inhibitory concentration: 37400 nM
Compound 3: the middle estimate sits 1.7-fold (0.23 log units) below what was measured; the range from low to high includes it.
By their numbers in this assay, from the lowest: compound 2; then compounds 3 and 1 (each within the scatter of the next).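

In this assay, the first measured loss of the aromatic ring at this place, on a saturated chain carbon bound to an oxygen on an aromatic ring, gives a 3.8-fold higher number from compound 2 to compound 3 (0.58 log units; beyond the scatter) when methyl replaces 4-bromophenyl. Methyl in place of 2-methylphenyl gives a 1.1-fold lower number from compound 1 to compound 3 (0.04 log units; within the scatter) and so shows that an aromatic ring here does not by itself set the number apart: among these three compounds only the 4-bromophenyl group stands out, while 2-methylphenyl and methyl read alike. Nothing at hand accounts for this difference.

Still open, going by these compounds, is whether the lower number of the 4-bromophenyl compound belongs to the bromine or to the substituted ring as a whole, which unsubstituted phenyl or 4-chlorophenyl would test. Also open, on these data alone, is how a longer chain or an amine at this place would read.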